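Furan-2-yl for phenyl on the lipid phosphate series

A few compounds are considered here, and "the series" means these few. Any claim that something is new, unique, unknown or untested is made for them only; others in the source may bear on it.

- compound 1 `OC[C@H]1O[C@@H](n2cc(F)c3c(-c4ccc[nH]4)ncnc32)[C@H](O)[C@@H]1O` gives 2990 nM
- compound 2 `CCCCCCCCCCCCCCCCCCOP(=O)(O)OC[C@H]1O[C@@H](n2ccc3c(-c4ccccc4)ncnc32)[C@H](O)[C@@H]1O` gives > 50000 nM (a limit, not a number)

Both values come from an ADME assay on BJ cells (Homo sapiens) for cytotoxicity, read by MTT assay, with a stated time of 72 h; on this read-out lower numbers stand for higher toxicity in this test and higher numbers for lower toxicity in this test. Compound 1 gives a measured number, 2990 nM. Within the data shown here, compound 2 stands only at a limit of the assay, > 50000 nM, and is the one compound at the limit of > 50000 nM in this assay, at which 1 of the 2 values shown sits.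

Compound 3 `CCCCCCCCCCCCCCCCCCOP(=O)(O)OC[C@H]1O[C@@H](n2ccc3c(-c4ccco4)ncnc32)[C@H](O)[C@@H]1O` has not yet been measured. It keeps the octadecyl phosphate of compound 2 and carries furan-2-yl in place of phenyl on an aromatic carbon.

Among the measured compounds shown here, no measured step shows what such an exchange does in this assay. The expectation therefore starts from compound 2 and its limit of > 50000 nM. No change beyond the usual scatter is expected, and any shift would more likely run toward lower numbers, since a compound starting at a limit has little visible room in the other direction. The estimated at least 1.2-fold lower number from compound 2 to compound 3 (0.09 log units; that floor lies within the scatter) is correspondingly small. A result reported only as a limit is also expected to be more likely than not. For compound 3 the estimated value is 40000 nM, with an expected range of 12000 nM to 60000 nM.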

Compound 3, half-maximal cytotoxic concentration: > 50000 nM
Compound 3: only a limit was reported (the forecaster's own chance of this, stated with the estimate: 60%); at least 1.2-fold (0.09 log units) between middle value and limit.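

In this assay compound 3 gives > 50000 nM, a limit and not a number. Compound 2 also stands at a limit, so the exchange of phenyl for furan-2-yl between compound 2 and compound 3 cannot be read as a step: the limit of > 50000 nM in this assay, at which 2 of the 3 values shown sit.

Still open, as far as these compounds go, is whether compound 2 and compound 3 differ at all in this read-out, and what number either would give.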